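This account rests on a few compounds, and the source may have more. Where it says the series, first, only, none or still open, it means among the compounds named here.

Measured so far:
compound 1, `O=S(=O)(Nc1ccc2oc(-c3ccc(NS(=O)(=O)c4ccc(Cl)s4)cc3)nc2c1)c1ccc(Cl)c(Cl)c1`: an assay for inhibition of HSP60/HSP10 (Homo sapiens), with a stated time of 60 min (on this read-out lower numbers stand for stronger inhibition and higher numbers for weaker inhibition), 4700 nM
compound 2, `O=S(=O)(Nc1ccc(-c2nc3cc(NS(=O)(=O)c4ccc(Cl)s4)ccc3o2)cc1)c1ccc(Cl)s1`: this assay 5900 nM

On the two numbers shown, compound 2 gives the larger, though the step of a 1.3-fold higher number from compound 1 to compound 2 (0.10 log units; within the scatter) keeps it within the scatter of compound 1, so the two are not separable. Compound 3, `O=S(=O)(Nc1ccc2oc(-c3ccc(NS(=O)(=O)c4ccc(Cl)s4)cc3)nc2c1)c1ccc(Cl)c(C(F)(F)F)c1`, is not yet measured. Its change from compound 2 is 4-chloro-3-(trifluoromethyl)phenyl in place of 5-chlorothiophen-2-yl on a sulfonyl sulfur. Among the measured compounds shown here, the only measured step at this sulfonyl sulfur is a 1.3-fold higher number from compound 1 to compound 2 (0.10 log units; within the scatter), which exchanged a six-membered aromatic ring of carbon only for the five-membered aromatic ring with one hetero atom without moving the number beyond the scatter. For the measured compounds named here, compound 3 returns to a six-membered aromatic ring of carbon only, now carrying a trifluoromethyl, for which no measured step exists. For compound 3 no step beyond the scatter is expected in this assay. Compound 3 is therefore estimated at 4800 nM, range 2000 nM to 11000 nM. The expected step is a 1.2-fold lower number from compound 2 to compound 3 (0.09 log units; within the scatter).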

Compound 3, half-maximal inhibitory concentration: 2400 nM
Beside the measured number, compound 3's estimate is 2.0-fold (0.30 log units) above it; measured number inside the range.
By their numbers in this assay, from the lowest: compounds 3, 1 and 2 (each within the scatter of the next, the first and the last beyond it).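

In this assay the sulfonyl sulfur now gives its first step beyond the scatter, though a modest one: a 2.5-fold lower number from compound 2 to compound 3 (0.39 log units; beyond the scatter) with 4-chloro-3-(trifluoromethyl)phenyl in place of 5-chlorothiophen-2-yl. Trifluoromethyl in place of chloro on an aromatic carbon gives a 2.0-fold lower number from compound 1 to compound 3 (0.29 log units; within the scatter), so these two substituents are not separated on this read-out, and only the pair at the ends of the series lies beyond the scatter. Nothing available here accounts for the step.

Open, on these data alone, is whether an amine or a carboxylic acid on the ring at this sulfonyl sulfur would keep the number in this range. Also open, as far as these compounds go, is how the number responds to a change at the other sulfonamide, which carries 5-chlorothiophen-2-yl in all three compounds.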